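From hydrogen to 4-cyanophenyl on the shared core

A few compounds are considered here, and "the series" means these few. Any claim that something is new, unique, unknown or untested is made for them only; others in the source may bear on it.

In a functional assay on NB-4 cells (Homo sapiens) for cytotoxicity, read by CCK-8 assay, with a stated time of 24 h (on this read-out lower numbers stand for stronger inhibition and higher numbers for weaker inhibition), compound 3 (`C=CC(=O)N1C(=O)CCSc2ccccc21`) gives 22400 nM, level within the scatter with compound 2 (`C=CC(=O)N1C(=O)CC(c2ccc(Cl)cc2)Sc2ccccc21`) at 22600 nM. Compound 1 (`C=CC(=O)N1C(=O)CC(c2ccc(Br)cc2)Sc2ccccc21`) gives a higher 59400 nM. Compound 4 (`C=CC(=O)N1C(=O)CC(c2ccc(C#N)cc2)Sc2ccccc21`) carries 4-cyanophenyl in place of hydrogen on a saturated ring carbon, next to the ring sulfur: 4-cyanophenyl in place of hydrogen on a saturated ring carbon. Among the compounds with values here, two measured steps bear on this change, read in reverse. Hydrogen in place of 4-chlorophenyl gave a 1.0-fold lower number from compound 2 to compound 3 (0.00 log units; within the scatter), and hydrogen in place of 4-bromophenyl gave a 2.7-fold lower number from compound 1 to compound 3 (0.42 log units; beyond the scatter). A small rise at most is therefore expected, probably within the scatter. The estimated change is a 1.3-fold higher number from compound 3 to compound 4 (0.13 log units; within the scatter). Compound 4 is expected at about 30000 nM, within an estimated range of 12000 nM to 70000 nM.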

Compound 4, half-maximal inhibitory concentration: 62400 nM
Estimate against measurement, compound 4: 2.1-fold (0.32 log units) below, and the stated range covers the measured number.
By their numbers in this assay, from the lowest: compounds 3 and 2 (each within the scatter of the next); then compounds 1 and 4 (each within the scatter of the next).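

In this assay, an aryl group on this saturated ring carbon does not always leave the number level: 4-cyanophenyl in place of hydrogen gives a 2.8-fold higher number from compound 3 to compound 4 (0.44 log units; beyond the scatter) as a step beyond the scatter, although compound 2 and compound 3 stand level. On the aromatic carbon, cyano in place of chloro gives a 2.8-fold higher number from compound 2 to compound 4 (0.44 log units; beyond the scatter) and so matches that rise, whereas cyano in place of bromo gives a 1.1-fold higher number from compound 1 to compound 4 (0.02 log units; within the scatter) and leaves compound 1 and compound 4 level, so compound 2 alone goes against the rise among the aryl compounds. No available evidence accounts for this difference.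

As far as these compounds go, whether an amine or a carboxylic acid on the aromatic ring would stand with chloro or with bromo and cyano remains open. So does the effect of an unsubstituted phenyl at this carbon.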